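The source may report more compounds than this note shows. Statements on the series, on what has been measured and on what is new or still open speak of the compounds shown alone.

In an assay on isolated protein for inhibition of eIF-2-alpha kinase GCN2 (Homo sapiens) (a higher number here means a weaker inhibitor, a lower number a stronger inhibitor), compound 3 `CNS(=O)(=O)[C@@H]1CC[C@@H](Nc2ncc3c(Br)nn(-c4ccc5ncccc5c4)c3n2)C1` gives 43 nM, the lowest of the two numbers measured. Compound 2 `COCc1noc([C@@H]2CC[C@@H](Nc3ncc4c(Br)nn(-c5ccc6ncccc6c5)c4n3)C2)n1` gives 106 nM in this assay. Compound 1 `COCCNC(=O)CNc1ncc2c(Br)nn(-c3ccc4ncccc4c3)c2n1` reaches only a limit in this assay, > 1000 nM. The step from compound 3 to compound 4 `CNC(=O)[C@]1(C)CC[C@@H](Nc2ncc3c(Br)nn(-c4ccc5ncccc5c4)c3n2)C1` is a group of 10 heavy atoms (8 carbon, 1 nitrogen, 1 oxygen; one five-membered non-aromatic ring of carbon only) in place of a group of 10 heavy atoms (6 carbon, 1 nitrogen, 2 oxygen, 1 sulfur; one five-membered non-aromatic ring of carbon only), on a nitrogen on an aromatic ring. Among the measured compounds shown here, two measured steps bear on changes at this position: an at least 23-fold lower number from compound 1 to compound 3 (1.36 log units; beyond the scatter), a large step from a chain without a ring, and a 2.5-fold lower number from compound 2 to compound 3 (0.39 log units; beyond the scatter), a modest step between two groups on the saturated ring carbon. Compound 4 keeps the five-membered ring and exchanges only the group on it, so a step of the modest kind is expected, most likely toward a somewhat higher number. Compound 4 is therefore estimated at 70 nM, with a range from 25 nM to 200 nM, which corresponds to an expected step of a 1.6-fold higher number from compound 3 to compound 4 (0.21 log units; within the scatter).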

Compound 4, half-maximal inhibitory concentration: 17 nM
Compound 4: middle estimate off by 4.1-fold (0.61 log units), on the high side; measured number outside the range, below it.
By their numbers in this assay, from the lowest: compound 4; then compound 3; then compound 2. At a limit, above all of these: compound 1.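

In this assay, the group on a nitrogen on an aromatic ring need not contain sulfur: with the five-membered ring kept, exchanging the group gives a 2.5-fold lower number from compound 3 to compound 4 (0.40 log units; beyond the scatter). Against the group with no ring, the result is an at least 58-fold lower number from compound 1 to compound 4 (1.76 log units; beyond the scatter). The value of compound 1 is a limit and not a number: the limit of > 1000 nM in this assay, at which 1 of the 4 values shown sits.

The compounds shown leave open how much of the step from compound 3 belongs to the amide and how much to the added methyl on the ring. Also open, on these data alone, is how an amine or a carboxylic acid in that place would compare.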